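The compounds below may be only part of what the source reports. "The series", "measured", "known", "first", "only" and "open" are said of these compounds alone.

Of the compounds shown here, three built on one shared core have been measured in a functional assay on MDA-MB-231 cells (Homo sapiens) for inhibition, read by MTT assay, with a stated time of 72 h; on this read-out higher numbers stand for weaker inhibition and lower numbers for stronger inhibition. Compound 1 `COc1ccccc1-c1csc2cnc(Nc3ccc(NC(=O)[C@@H]4CCCNC4)cc3)nc12` gives 410 nM. Compound 2 `COc1ccccc1-c1csc2cnc(Nc3ccc(NC(=O)CN)cc3)nc12` gives 2770 nM, and compound 3 `COc1ccccc1-c1csc2cnc(Nc3ccc(C(=O)NC4CCNCC4)cc3F)nc12` gives 1610 nM. Among these three numbers compound 2 stands highest; its gap to compound 3 lies within the scatter, while its gap to compound 1 lies beyond it. Going by the values given here, the only measured step that bears on the change followed here is a 6.8-fold higher number from compound 1 to compound 2 (0.83 log units; beyond the scatter). Compound 4 `COc1ccccc1-c1csc2cnc(Nc3ccc(NC(=O)[C@H]4CCCNC4)cc3)nc12` arises from compound 2 by piperidin-3-yl in place of aminomethyl on a carbonyl carbon. Among the compounds with values here, the piperidin-3-yl that enters carries a defined stereocentre, and in compound 4 that centre takes the opposite arrangement to the one in compound 1; no measured pair shows how much that arrangement alone matters. Because the step of a 6.8-fold higher number from compound 1 to compound 2 (0.83 log units; beyond the scatter) was modest and beyond the scatter, reversing that exchange is expected to lower the number, though the changed arrangement leaves the size uncertain and the result could fall anywhere between the numbers of compound 1 and compound 2. The estimated step is a 3.7-fold lower number from compound 2 to compound 4 (0.57 log units; beyond the scatter). Compound 4 is therefore expected to give about 750 nM, within a range from 250 nM to 2500 nM.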

Compound 4, half-maximal inhibitory concentration: 440 nM
Estimate against measurement, compound 4: 1.7-fold (0.23 log units) above; the range from low to high includes it.
By their numbers in this assay, from the lowest: compounds 1 and 4 (each within the scatter of the next); then compounds 3 and 2 (each within the scatter of the next).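

In this assay, the exchange of aminomethyl for piperidin-3-yl on a carbonyl carbon now has a reading for a second arrangement of the ring's stereocentre, and the stronger result holds there too: the step is a 6.3-fold lower number from compound 2 to compound 4 (0.80 log units; beyond the scatter). The earlier compounds shown here could not show how much that arrangement alone matters, and here it makes no difference that can be told from the scatter, the step being a 1.1-fold higher number from compound 1 to compound 4 (0.03 log units; within the scatter). Among these compounds, the stronger read-out therefore goes with the piperidin-3-yl ring in either arrangement, and this pair can be read as a test of the arrangement alone because of one fact: the fact that compounds 1 and 4 differ only in the configuration as drawn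

Still open, as far as these compounds go, is whether the ring itself matters, or whether another group on that carbonyl carbon, such as a longer open chain ending in an amine or a piperidin-4-yl, would serve as well. The role of the ring nitrogen is also unsettled, and a cyclohexyl group, with carbon in place of that nitrogen, would test it directly.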